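From methoxy to dimethylamino: compound 3 to compound 4

The source may hold more compounds than are shown below. What is called first, only, known or untested is meant among the compounds shown, and "the series" means these compounds.

Compound 1 `C/C(=N\NC(=O)/C(C#N)=C/c1ccc(O)cc1)c1c(O)c2ccc(O)cc2oc1=O`: 6230 nM
Compound 2 `COc1cc(/C=C(\C#N)C(=O)N/N=C(\C)c2c(O)c3ccc(O)cc3oc2=O)ccc1O`: 12600 nM
Compound 3 `COc1ccc(/C=C(\C#N)C(=O)N/N=C(\C)c2c(O)c3ccc(O)cc3oc2=O)cc1`: 8150 nM

In a functional assay on A549 cells (Homo sapiens) for cytotoxicity, read by MTT assay, with a stated time of 24 h (a higher number here means a weaker inhibitor, a lower number a stronger inhibitor), compound 3 gives 8150 nM, within the scatter of both other compounds, whose own gap is a 2.0-fold higher number from compound 1 to compound 2 (0.31 log units; beyond the scatter). Compound 4 `C/C(=N\NC(=O)/C(C#N)=C/c1ccc(N(C)C)cc1)c1c(O)c2ccc(O)cc2oc1=O` carries a single change, dimethylamino in place of methoxy on an aromatic carbon. For the measured compounds named here, no measured step makes this exact swap. The closest steps change substituents on the same aromatic ring: a 1.3-fold higher number from compound 1 to compound 3 (0.12 log units; within the scatter), and a 1.5-fold lower number from compound 2 to compound 3 (0.19 log units; within the scatter). Both lie within the scatter, so no step beyond it is expected. The estimated step is a 1.2-fold lower number from compound 3 to compound 4 (0.07 log units; within the scatter). For compound 4 the expected value is 7000 nM, with an estimated range from 3000 nM to 16000 nM.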

Compound 4, half-maximal inhibitory concentration: 4310 nM
Compound 4: middle estimate off by 1.6-fold (0.21 log units), on the high side; the range from low to high includes it.
By their numbers in this assay, from the lowest: compounds 4, 1, 3 and 2 (each within the scatter of the next, the first and the last beyond it).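

In this assay, dimethylamino on this aromatic carbon, para to a large group, brings a nitrogen substituent to the position and stays within the scatter of both methoxy (a 1.9-fold lower number from compound 3 to compound 4 (0.28 log units; within the scatter)) and hydroxy (a 1.4-fold lower number from compound 1 to compound 4 (0.16 log units; within the scatter)). Only the larger change from 4-hydroxy-3-methoxyphenyl to 4-(dimethylamino)phenyl goes beyond the scatter (a 2.9-fold lower number from compound 2 to compound 4 (0.47 log units; beyond the scatter)). No evidence is available to explain these steps. The compounds shown leave open whether a piperidine ring or a carboxylic acid at this position would step beyond the scatter of compound 4.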